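Aryl swap at the bicyclic core: compound 2 to compound 3

This account rests on a few compounds, and the source may have more. Where it says the series, first, only, none or still open, it means among the compounds named here.

Of the compounds shown here, two have been measured in a functional assay on HCT-15 cells (Homo sapiens) for inhibition, read by sulforhodamine B assay, with a stated time of 48 h, tested at 10 uM; a lower number here means less inhibition, a higher number more inhibition at the concentration tested (going by the name of the read-out). Compound 1 `COc1ccc(-c2cn3ccnc3c(-c3ccc4ncn(C5CCCCC5)c4c3)n2)cc1` gives 78.8%. Within the data shown here, compound 2 `Fc1ccccc1-c1cn2ccnc2c(-c2ccc3ncn(C4CCCCC4)c3c2)n1` gives 6.18%, the lower of the two numbers; the only recorded step is a number 72.6 percentage points lower from compound 1 to compound 2 (beyond the scatter), so compound 2 stands far beneath compound 1.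

Compound 3 `FC(F)(F)c1cccc(-c2cn3ccnc3c(-c3ccc4ncn(C5CCCCC5)c4c3)n2)c1` is derived from compound 2 by the change (3-(trifluoromethyl)phenyl in place of 2-fluorophenyl on an aromatic carbon). Among the measured compounds shown here, no measured step matches this change: the one step known alters the same aryl group, but between a different pair of groups, and it was large, a number 72.6 percentage points lower from compound 1 to compound 2 (beyond the scatter). It shows only that the identity of this aryl group can move the read-out strongly; it does not show in which direction a trifluoromethyl-bearing ring will move it from the low level of compound 2.

Given that, the expectation for compound 3 is a moderate rise from compound 2, a number 23.8 percentage points higher from compound 2 to compound 3 (beyond the scatter), with wide uncertainty. The estimated value for compound 3 is 30%, within a range from 0% to 75%.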

Compound 3, a percentage reported as inhibition, at one concentration (the size of the read-out at that concentration, not a potency): 0.36%
For compound 3 the middle estimate is 29.6 percentage points above the measured one; the measured number falls inside the stated range.
By their numbers in this assay, from the lowest: compounds 3 and 2 (each within the scatter of the next); then compound 1.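

In this assay, the 3-(trifluoromethyl)phenyl and 2-fluorophenyl groups cannot be told apart at this position: a number 5.8 percentage points lower from compound 2 to compound 3 (within the scatter). Replacing the 4-methoxyphenyl group with 3-(trifluoromethyl)phenyl gives a large step, a number 78.4 percentage points lower from compound 1 to compound 3 (beyond the scatter), so among the three compounds both replacements of the 4-methoxyphenyl group end far beneath compound 1, and none goes against this. The data at hand offer nothing that explains this pattern at the position.

With a different ring substituent and a different place on the ring in each compound, the series leaves open whether the number of compound 1 depends on the methoxy group, on where it sits, or on both; a 3-methoxyphenyl or a 4-fluorophenyl group would separate these. Also open, on these data alone, is whether a group of another kind on the same ring, such as an amine or a carboxylic acid, could reach the level of compound 1, and how these compounds would rank across a range of concentrations rather than at the single one tested.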